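Compound 4: does moving the trifluoromethyl group matter?

The compounds below may be only part of what the source reports. "The series", "measured", "known", "first", "only" and "open" are said of these compounds alone.

Compound 1 `CC(O)(CS(=O)(=O)c1cccc(S(F)(F)(F)(F)F)c1)C(=O)Nc1ccc(S(F)(F)(F)(F)F)cc1` gives 24800 nM
Compound 2 `CC(O)(CS(=O)(=O)c1ccc(F)cc1)C(=O)Nc1ccc(S(F)(F)(F)(F)F)cc1` gives 34200 nM
Compound 3 `CC(O)(CS(=O)(=O)c1ccc(C(F)(F)F)cc1)C(=O)Nc1ccc(S(F)(F)(F)(F)F)cc1` gives 27700 nM

These three values come from a functional assay on VCaP cells (Homo sapiens) for antiproliferative activity, read by propidium iodide staining, with a stated time of 96 h (a higher number here means a weaker inhibitor, a lower number a stronger inhibitor), and the compounds differ only in the group on the sulfonyl sulfur. Compound 3 stands within the usual scatter of both compound 1 and compound 2, so the three cannot be told apart.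

In compound 4 `CC(O)(CS(=O)(=O)c1cccc(C(F)(F)F)c1)C(=O)Nc1ccc(S(F)(F)(F)(F)F)cc1`, not yet measured, 3-(trifluoromethyl)phenyl takes the place of 4-(trifluoromethyl)phenyl on a sulfonyl sulfur 3-(trifluoromethyl)phenyl in place of 4-(trifluoromethyl)phenyl on a sulfonyl sulfur and the same atoms are simply joined differently.

Among the compounds with values here, the one measured step that bears on this is a 1.2-fold lower number from compound 2 to compound 3 (0.09 log units; within the scatter) and it stays within the scatter, even though it swaps fluoro for trifluoromethyl. Within the data shown here, no measured pair shows this exact kind of change, so the evidence is indirect.

The estimated step of a 1.0-fold lower number from compound 3 to compound 4 (0.01 log units; within the scatter) is expected to stay within the scatter in this assay with no direction favoured.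

Compound 4 is expected at 27000 nM with an estimated range of 14000 nM to 50000 nM around that figure.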

Compound 4, half-maximal inhibitory concentration: 32000 nM
Compound 4: the middle estimate sits 1.2-fold (0.07 log units) below what was measured; the range from low to high includes it.
By their numbers in this assay, from the lowest: compounds 1, 3, 4 and 2 (each within the scatter of the next).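

In this assay the trifluoromethyl group can sit in either printed position: 3-(trifluoromethyl)phenyl in place of 4-(trifluoromethyl)phenyl on a sulfonyl sulfur gives a 1.2-fold higher number from compound 3 to compound 4 (0.06 log units; within the scatter) and so leaves no readable difference. The other two changes that reach this new compound are just as silent, with 3-(trifluoromethyl)phenyl in place of 4-fluorophenyl giving a 1.1-fold lower number from compound 2 to compound 4 (0.03 log units; within the scatter) and trifluoromethyl in place of pentafluorosulfanyl on an aromatic carbon giving a 1.3-fold higher number from compound 1 to compound 4 (0.11 log units; within the scatter) in the same test. No measurement shown offers any explanation for this flatness.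

Every group shown on the sulfonyl sulfur is a phenyl ring carrying fluoro, trifluoromethyl or pentafluorosulfanyl. Going by these compounds, the effect of an amine or a carboxylic acid on that ring, or of a saturated chain in place of the ring, remains open.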